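Series notes: hexylamino in place of morpholin-4-yl

A few compounds are considered here, and "the series" means these few. Any claim that something is new, unique, unknown or untested is made for them only; others in the source may bear on it.

Within the data shown here, compound 1 `CCCCCCCCCCCCCCCCCCN(C)S(=O)(=O)NC(=O)Nc1c(C(C)C)cccc1C(C)C` is the one member of the series with a numerical result: in an assay on liver for inhibition of sterol O-acyltransferase 1 (Rattus norvegicus), using microsomes (a lower number here means a stronger inhibitor, a higher number a weaker inhibitor), compound 1 gives 1900 nM. Compound 2 `CC(C)c1cccc(C(C)C)c1OC(=O)NS(=O)(=O)N1CCCCC1` shares the core and carries piperidin-1-yl on the sulfonyl sulfur. In this assay compound 2 reaches only the limit > 100000 nM, which is a limit of the measurement and not a number. Compound 3 `CC(C)c1cccc(C(C)C)c1OC(=O)NS(=O)(=O)N1CCOCC1` carries morpholin-4-yl in the same place. In this assay compound 3 likewise stops at the limit > 100000 nM, again a limit rather than a number. The step that the two limits leave unreadable from compound 2 to compound 3 therefore cannot be read, since both ends sit at the limit of > 100000 nM in this assay, at which 2 of the 3 values shown sit. Compound 3 thus has no numerical potency of its own; its standing in the series is defined by that limit alone.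

Compound 4 `CCCCCCNS(=O)(=O)NC(=O)Oc1c(C(C)C)cccc1C(C)C` differs from compound 3 by hexylamino in place of morpholin-4-yl on a sulfonyl sulfur. Among the measured compounds shown here, no measured step covers this change: the pair compound 1 against compound 3 differs in more than one place, and the step between piperidin-1-yl and morpholin-4-yl offers no size. The expectation for compound 4 is therefore a modest gain at most, an at least 3.3-fold lower number from compound 3 to compound 4 (0.52 log units; beyond the scatter), with a real chance that only a limit is returned again. Compound 4 is estimated at 30000 nM, between 3000 nM and 100000 nM.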

Compound 4, half-maximal inhibitory concentration: 21000 nM
The estimate for compound 4 lay 1.4-fold (0.15 log units) above the measured number, within the range that was stated.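

In this assay, the place on the sulfonyl sulfur now gives its first readable change within the carbamate-linked compounds, with an at least 4.7-fold lower number from compound 3 to compound 4 (0.67 log units; beyond the scatter) and an at least 4.7-fold lower number from compound 2 to compound 4 (0.67 log units; beyond the scatter). Among these compounds, compound 4 is thus the first member with this linkage to return a number, and its open hexylamino chain has no ring, unlike the morpholin-4-yl and piperidin-1-yl groups it is compared with, and also carries a hydrogen-bond donor that those two groups lack. Both step sizes are lower bounds only, since each starts from a limit and not from a number, and the step between the two ring compounds cannot be read: the limit of > 100000 nM in this assay, at which 2 of the 4 values shown sit.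

The compounds shown leave open whether the gain follows from losing the ring or from the donor on the hexylamino nitrogen, a question that a methyl(hexyl)amino group in the same place would separate. They also leave open how the number responds to chain length on the sulfonyl sulfur, for which octylamino or dodecylamino on the core of compound 4 would be the direct comparison.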